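A few compounds are considered here, and "the series" means these few. Any claim that something is new, unique, unknown or untested is made for them only; others in the source may bear on it.

Three compounds of the series have so far been run in an ADME assay on TZM cells (Homo sapiens) for cytotoxicity, read by XTT assay, with a stated time of 4 days; a lower number here means that less compound is tolerated, a higher number that more compound is tolerated. Compound 1 `Cc1cc(CCC#N)cc(C)c1Oc1cc(Nc2ccc(C#N)cc2)c(N)cc1C(F)(F)F` gives > 7100 nM, which is a limit of the assay rather than a number. Compound 2 `COC(=O)c1cc(N)c(Nc2ccc(C#N)cc2)cc1Oc1c(C)cc(CCC#N)cc1C` gives > 22700 nM, again a limit. Compound 3 `COC(=O)c1cc(N)c(Nc2ccc(C#N)cc2)cc1Oc1c(C)cc(/C=C/C#N)cc1C` gives > 22800 nM, also a limit. The change trifluoromethyl in place of methoxycarbonyl on an aromatic carbon yields a step that the two limits leave unreadable from compound 2 to compound 1. The change 2-cyanoethenyl in place of 2-cyanoethyl on an aromatic carbon yields a step that the two limits leave unreadable from compound 2 to compound 3, and this is how the cores of compound 2 and compound 3 differ. Compound 4 `Cc1cc(/C=C/C#N)cc(C)c1Oc1cc(Nc2ccc(C#N)cc2)c(N)cc1C(F)(F)F` remains unmeasured; it differs from compound 3 by trifluoromethyl in place of methoxycarbonyl on an aromatic carbon, the same change that separates compound 1 from compound 2. Because compound 1 sits at the limit of > 7100 nM in this assay, at which 1 of the 3 values shown sits, while compound 3 sits at the limit of > 22800 nM in this assay, at which 1 of the 3 values shown sits, the step from compound 3 to compound 4 in this assay is expected to be an at least 1.1-fold lower number from compound 3 to compound 4 (0.05 log units; that floor lies within the scatter), most likely again unreadable. Compound 4 is estimated at 20000 nM, probably reported only as a limit.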

Compound 4, half-maximal cytotoxic concentration in the TZM assay: 15000 nM
Compound 4: middle estimate off by 1.3-fold (0.12 log units), on the high side, and the stated range covers the measured number.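

In the TZM assay compound 3 gives > 22800 nM, which is a limit of the assay. In the TZM assay compound 4 gives 15000 nM. In the TZM assay, trifluoromethyl in place of methoxycarbonyl on the core of compound 3 gives an at least 1.5-fold lower number from compound 3 to compound 4 (0.18 log units; that floor lies within the scatter), so this core offers only a floor that lies within the scatter. The same change from compound 2 to compound 1 rests on limits of the assay, as does the step from compound 1 to compound 4; these steps cannot be read, so nothing shows whether the change behaves alike on the two cores. In a physicochemical assay for solubility, with a stated time of 4 h, at pH 2.0 (a lower number here means a less soluble compound, a higher number a more soluble compound), compound 3 gives 1.75 ug/mL and compound 4 gives 0.42 ug/mL. In the physicochemical assay the change gives a 4.2-fold lower number from compound 3 to compound 4 (0.62 log units; beyond the scatter), which is a single pair on a single core and no pattern for the series.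

Open, going by these compounds, is whether a step of this size in the physicochemical assay also holds between compound 2 and compound 1. Also open, on these data alone, is how a carboxylic acid or an amine would behave on that same aromatic carbon in either assay.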